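The compounds below may be only part of what the source reports. "The series", "measured", "known", "first", "only" and "open" are said of these compounds alone.

Working notes on the series. The shared core of compound 1 `COc1cc(-c2cccc3nc(-c4cccc(F)c4)oc23)cc(OC)c1OC` carries 3-fluorophenyl; compound 2 `COc1cc(-c2cccc3nc(-c4ccc(F)cc4)oc23)cc(OC)c1OC` carries 4-fluorophenyl and compound 3 `COc1cc(-c2cccc3nc(-c4ccc(Cl)cc4)oc23)cc(OC)c1OC` carries 4-chlorophenyl. In a functional assay on A549 cells (Homo sapiens) for antiproliferative activity, read by MTT assay, with a stated time of 48 h (on this read-out lower numbers stand for stronger inhibition and higher numbers for weaker inhibition), compound 1 gives 2600 nM, compound 2 gives 8700 nM and compound 3 gives 5600 nM. Compound 3 stands second highest of the three numbers: toward compound 2 the change is a 1.6-fold lower number from compound 2 to compound 3 (0.19 log units; within the scatter), within the scatter, whereas toward compound 1 the gap is a 2.2-fold higher number from compound 1 to compound 3 (0.33 log units; beyond the scatter), beyond it. The remaining step, a 3.3-fold higher number from compound 1 to compound 2 (0.52 log units; beyond the scatter), points the same way, so in these three compounds the 3-fluorophenyl compound gives the lowest number and the two others sit close together.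

Compound 4 `COc1cc(-c2cccc3nc(-c4cccs4)oc23)cc(OC)c1OC` introduces the change (thiophen-2-yl in place of 4-chlorophenyl on an aromatic carbon). Among the measured compounds shown here, no measured step exchanges a six-membered aromatic ring for a five-membered one, so nothing bears on it directly. The closest guide is a 1.6-fold lower number from compound 2 to compound 3 (0.19 log units; within the scatter), which shows that swapping one group for another on this aromatic carbon can leave the number within the scatter, while a 2.2-fold higher number from compound 1 to compound 3 (0.33 log units; beyond the scatter) shows that such swaps can also move it by a modest amount. A step within the scatter is expected for a 1.1-fold lower number from compound 3 to compound 4 (0.05 log units; within the scatter), with no direction favoured. Compound 4 is therefore estimated at 5000 nM, between 1800 nM and 14000 nM.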

Compound 4, half-maximal inhibitory concentration: 12500 nM
Compound 4: the middle estimate sits 2.5-fold (0.40 log units) below what was measured; measured number inside the range.
By their numbers in this assay, from the lowest: compound 1; then compounds 3, 2 and 4 (each within the scatter of the next, the first and the last beyond it).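

Thiophen-2-yl is the first five-membered aromatic ring at this carbon of the five-membered ring bearing the nitrogen and oxygen, and the exchange does not read the same against each phenyl compound in this assay: a 2.2-fold higher number from compound 3 to compound 4 (0.35 log units; beyond the scatter) is a modest step beyond the scatter, a 1.4-fold higher number from compound 2 to compound 4 (0.16 log units; within the scatter) stays within it, and a 4.8-fold higher number from compound 1 to compound 4 (0.68 log units; beyond the scatter) is the largest step among the four compounds. Among the compounds shown here, replacing the six-membered ring with thiophen-2-yl therefore gives no gain over any of the three phenyl compounds, and 3-fluorophenyl remains the only group here whose number lies beyond the scatter of all the others, so the substitution on the phenyl ring matters at least as much as the ring exchange itself. Nothing available explains these steps, and the role of the sulfur atom or of the smaller ring cannot be separated from these values.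

Open, from the compounds shown here alone, is whether furan-2-yl, thiophen-3-yl or a pyridine ring would read like thiophen-2-yl, since a single five-membered example cannot define the ring type. Also open, going by these compounds, is whether 3-chlorophenyl, or an amine or carboxylic acid on the phenyl ring, would hold or lower the number of compound 1.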